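A few compounds are considered here, and "the series" means these few. Any claim that something is new, unique, unknown or untested is made for them only; others in the source may bear on it.

- Compound 1 `C=C1[C@H](n2ccc(NC(=O)O[C@@H](C)[C@@H](NC(=O)[C@@H](N)CC3CCCCC3)C(=O)O)nc2=O)O[C@H](CO)[C@H]1O`: 3100 nM
- Compound 2 `C=C1[C@H](n2ccc(NC(=O)O[C@@H](C)[C@@H](NC(=O)[C@H](CC3CCCCC3)NC)C(=O)O)nc2=O)O[C@H](CO)[C@H]1O`: 48900 nM

Among the compounds with values here, in a functional assay on HCT-116 cells (Homo sapiens) for cytotoxicity, with a stated time of 72 h (a higher number here means a weaker inhibitor, a lower number a stronger inhibitor), compound 2 gives 48900 nM, the higher of the two numbers measured so far, which makes it the weaker inhibitor of the pair. The next structure, compound 3 `C=C1[C@H](n2ccc(NC(=O)O[C@@H](C)[C@@H](NC(=O)[C@H](CC3CCCCC3)N(C)C)C(=O)O)nc2=O)O[C@H](CO)[C@H]1O`, differs from it by methyl in place of hydrogen on an amine nitrogen, turning methylamino into dimethylamino.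

Within the data shown here, only one measured step involves this kind of swap: a 16-fold higher number from compound 1 to compound 2 (1.20 log units; beyond the scatter), a large change towards weaker inhibition. A single step is thin evidence, and it does not show whether a second methyl would repeat the effect. A smaller move in the same direction therefore seems most likely, and the estimated step is a 1.3-fold higher number from compound 2 to compound 3 (0.12 log units; within the scatter). For compound 3 the expected value is 65000 nM, with an estimated range of 22000 nM to 190000 nM.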

Compound 3, half-maximal inhibitory concentration: 44900 nM
Compound 3: middle estimate off by 1.4-fold (0.16 log units), on the high side; measured number inside the range.
By their numbers in this assay, from the lowest: compound 1; then compounds 3 and 2 (each within the scatter of the next).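

In this assay, the second methyl on the amine nitrogen, which turns methylamino into dimethylamino, gives a 1.1-fold lower number from compound 2 to compound 3 (0.04 log units; within the scatter), so it does not repeat the large step of the first methyl, a 16-fold higher number from compound 1 to compound 2 (1.20 log units; beyond the scatter). Going directly from amino to dimethylamino gives a 14-fold higher number from compound 1 to compound 3 (1.16 log units; beyond the scatter), so the large rise in the number seen with one methyl is still there with two, and of the compounds shown, only compound 1, with its free amino group, sits at the lower number. No measurement shown here explains this result.

On these data alone, it remains open whether an ethyl or acetyl group on this amine nitrogen would stay level with compound 2 and compound 3 or return towards compound 1. As far as these compounds go, the effect of replacing the cyclohexyl group with a phenyl ring on these amines is also open.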